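A few compounds are considered here, and "the series" means these few. Any claim that something is new, unique, unknown or untested is made for them only; others in the source may bear on it.

Measured so far:
Compound 1, `O=C(O)c1ccc(-c2cccc(COc3ccc4c(c3)CN(C3CCCC3)C4=O)c2)c(Cl)c1`: 3%
Compound 2, `O=C(O)c1cc(-c2cccc(COc3ccc4c(=O)n(C5CC5)sc4c3)c2)ccc1Cl`: 86%

In an ADME assay on microsomes from liver (Rattus norvegicus) for metabolic stability, read by LC-MS, with a stated time of 1 h, at 37 degrees C, tested at 4 uM (on this read-out higher numbers stand for a more stable compound and lower numbers for a less stable compound), compound 1 gives 3%, the lower of the two numbers, while compound 2 gives 86%, far higher and well beyond the usual scatter. Compound 3, `COc1ccc(C(=O)O)cc1-c1cccc(COc2ccc3c(c2)CN(C2CCCC2)C3=O)c1`, differs from compound 1 in one place: 5-carboxy-2-methoxyphenyl in place of 4-carboxy-2-chlorophenyl on an aromatic carbon. Among the compounds with values here, no two measured compounds differ in only one place, so the size of this step is uncertain; a modest rise, close to the edge of the scatter, is expected, a number 12 percentage points higher from compound 1 to compound 3 (beyond the scatter). For compound 3 the estimated value is 15%, expected to lie between 3% and 45%.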

Compound 3, percent of the compound remaining: 30%
For compound 3 the middle estimate is 15 percentage points below the measured one, and the stated range covers the measured number.
By their numbers in this assay, from the lowest: compound 1; then compound 3; then compound 2.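

In this assay, putting 5-carboxy-2-methoxyphenyl in place of 4-carboxy-2-chlorophenyl gives a number 27 percentage points higher from compound 1 to compound 3 (beyond the scatter), so the group on this aromatic carbon affects the read-out while the rest of the molecule stays the same. The change does two things at once: a methoxy replaces the chlorine, and the carboxy group sits at a different ring position. No available evidence explains the rise. The compounds shown leave open which of these two differences carries the step. A 4-carboxy-2-methoxyphenyl group would help to separate them.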